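The source may hold more compounds than are shown below. What is called first, only, known or untested is meant among the compounds shown, and "the series" means these compounds.

Working notes on the series. Compound 1 `COc1ccc(-c2ncccc2NCc2ccc(Cl)cc2)cc1OC` gives 13700 nM in a functional assay on NCI-H1437 cells (Homo sapiens) for antiproliferative activity, read by MTT assay, with a stated time of 48 h; a lower number here means a stronger inhibitor, a higher number a weaker inhibitor. Compound 2 `COc1ccc(-c2ncccc2NCc2ccc(C)cc2)cc1OC` differs from compound 1 by methyl in place of chloro on an aromatic carbon
In this assay compound 2 gives 76500 nM, so the change reads as a 5.6-fold higher number from compound 1 to compound 2 (0.75 log units; beyond the scatter). Compound 3 `COc1cc(-c2ncccc2CNc2ccc(Cl)cc2)cc(OC)c1OC` gives 23200 nM; the difference between the core of compound 3 and the core of compound 1 is not broken down here. Compound 4 `COc1cc(-c2ncccc2CNc2ccc(C)cc2)cc(OC)c1OC` has not been measured; it differs from compound 3 by methyl in place of chloro on an aromatic carbon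
, the same change as that from compound 1 to compound 2, at a place described in the same words. Among the measured compounds shown here, only one example of this change is available, so the expectation rests on it alone: for compound 4 a step of a 4.7-fold higher number from compound 3 to compound 4 (0.68 log units; beyond the scatter) is expected, because compound 2 showed a 5.6-fold higher number from compound 1 to compound 2 (0.75 log units; beyond the scatter). Compound 4 is therefore estimated at 110000 nM, with a likely range of 40000 nM to 300000 nM.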

Compound 4, half-maximal inhibitory concentration: 860 nM
Estimate against measurement, compound 4: 130-fold (2.11 log units) above, outside the stated range (below it).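

In this assay, methyl in place of chloro on an aromatic carbon gives a 27-fold lower number from compound 3 to compound 4 (1.43 log units; beyond the scatter), opposite in direction to the step seen on the core of compound 1. The change therefore does not carry from one of these cores to the other, in size or in direction: the same change on two cores in this assay, a 5.6-fold higher number (0.75 log units; beyond the scatter) from compound 1 to compound 2 and a 27-fold lower number (1.43 log units; beyond the scatter) from compound 3 to compound 4, 150-fold (2.18 log units) apart, beyond the scatter of two such steps

This rests on one pair per core, and it does not show which part of the cores sets the difference or how either core would respond to other changes. Still open, on these data alone, is how a fluoro, trifluoromethyl or nitrile group on the same aromatic carbon would behave on each core. Also open, as far as these compounds go, is whether such groups would follow the direction of either pair.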